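Swapping 2-Chlorophenyl for Pyridin-3-yl in Compound 3

This account rests on a few compounds, and the source may have more. Where it says the series, first, only, none or still open, it means among the compounds named here.

Among the compounds with values here, compound 2 `Cc1nn(-c2nc(-c3ccc(Cl)c(Cl)c3)c(SC(C)C)s2)c(C(=O)O)c1-c1ccccc1Cl` gives 13100 nM in a functional assay on BJAB cells (Homo sapiens) for antiproliferative activity, with a stated time of 4 days (on this read-out higher numbers stand for an effect only at larger amounts of compound and lower numbers for an effect already at smaller amounts), the highest of the two numbers measured so far. Compound 1 `Cc1cc(C#N)cc(-c2c(C)nn(-c3nc(-c4ccc(Cl)c(Cl)c4)c(SC(C)C)s3)c2C(=O)O)c1` gives 4800 nM in this assay. Within the data shown here, the one measured step, a 2.7-fold higher number from compound 1 to compound 2 (0.44 log units; beyond the scatter), shows that changing the aromatic group at this position shifts the number only modestly. Compound 3 `Cc1nn(-c2nc(-c3ccc(Cl)c(Cl)c3)c(SC(C)C)s2)c(C(=O)O)c1-c1cccnc1` differs from compound 2 by pyridin-3-yl in place of 2-chlorophenyl on an aromatic carbon. Among the measured compounds shown here, no measured step covers this exact swap, so only a modest shift in either direction is expected. Compound 3 is therefore estimated at 15000 nM, with a range from 5000 nM to 45000 nM. This corresponds to an expected step of a 1.1-fold higher number from compound 2 to compound 3 (0.06 log units; within the scatter).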

Compound 3, half-maximal effective concentration: 12000 nM
Estimate against measurement, compound 3: 1.3-fold (0.10 log units) above, and the stated range covers the measured number.
By their numbers in this assay, from the lowest: compound 1; then compounds 3 and 2 (each within the scatter of the next).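

In this assay, the swap gives a 1.1-fold lower number from compound 2 to compound 3 (0.04 log units; within the scatter), so pyridin-3-yl, with its hydrogen-bond acceptor, and 2-chlorophenyl cannot be told apart at this aromatic carbon. The step to the 3-cyano-5-methylphenyl compound is a 2.5-fold higher number from compound 1 to compound 3 (0.40 log units; beyond the scatter), which leaves compound 1 with the lowest number of the three. No measurement here explains either result.

Going by these compounds, it remains open whether a group without an aromatic ring at this carbon, such as an amine, would shift the number further. On these data alone, it is also open whether the nitrile or the methyl group in compound 1 matters more.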